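The source may report more compounds than this note shows. Statements on the series, on what has been measured and on what is new or still open speak of the compounds shown alone.

Among the measured compounds shown here, compound 1, with the structure `CNc1cc(Oc2c(OC)cc3cc(C#N)ccc3c2OC)nc(Nc2ccc(C#N)cc2)n1`, is the only member of this small set for which an ADME assay on MT4 cells (Homo sapiens) for cytotoxicity, read by MTT assay, with a stated time of 5 days (on this read-out lower numbers stand for higher toxicity in this test and higher numbers for lower toxicity in this test), returns a number: compound 1 gives 239000 nM. Compound 2, `CCCCCNc1cc(Oc2c(OC)cc3cc(C#N)ccc3c2OC)nc(Nc2ccc(C#N)cc2)n1`, reaches only a limit of the assay in this assay, reported as > 125000 nM. Compound 3, `CCCC(C)Nc1cc(Oc2c(OC)cc3cc(C#N)ccc3c2OC)nc(Nc2ccc(C#N)cc2)n1`, likewise stops at a limit in this assay, given as > 125000 nM. The step that the limit leaves unreadable from compound 1 to compound 2 and the step that the limit leaves unreadable from compound 1 to compound 3 therefore cannot be sized, and the same holds for a step that the two limits leave unreadable from compound 2 to compound 3; what can be said is only that (the limit of > 125000 nM in this assay, at which 2 of the 3 values shown sit), so that every compound in the set sits at the weakly toxic end of what the test resolves.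

Compound 4, `COc1cc2cc(C#N)ccc2c(OC)c1Oc1cc(NC2CCOC2)nc(Nc2ccc(C#N)cc2)n1`, carries the change (oxolan-3-yl in place of methyl on a nitrogen on an aromatic ring). For the measured compounds named here, no measured step bears on this change directly; the two steps that do alter the same nitrogen, from compound 1 to compound 2 and from compound 1 to compound 3, are unreadable because of the limit of > 125000 nM in this assay, at which 2 of the 3 values shown sit. The expectation for compound 4 is thus a step of a 1.2-fold lower number from compound 1 to compound 4 (0.08 log units; within the scatter) of no size beyond the scatter, with a real chance that only a limit is returned. Compound 4 is estimated at 200000 nM, in the range 100000 nM to 400000 nM.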

Compound 4, half-maximal cytotoxic concentration: > 125000 nM
Compound 4 ended at the assay's limit; the forecaster's own chance of this, stated with the estimate: 50%; the middle value does not contradict the limit.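

In this assay, among the compounds shown here, compound 4 returns only a limit of > 125000 nM and no step from compound 1, compound 2 or compound 3 to compound 4 can be read: the limit of > 125000 nM in this assay, at which 3 of the 4 values shown sit. The compounds shown leave open whether the pentyl, 1-methylbutyl and oxolan-3-yl compounds differ from compound 1 or from one another.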